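A few compounds are considered here, and "the series" means these few. Any claim that something is new, unique, unknown or untested is made for them only; others in the source may bear on it.

Working notes on the series in a functional assay on SUP-B15 cells (Homo sapiens) for antiproliferative activity, with a stated time of 72 h; on this read-out lower numbers stand for an effect already at smaller amounts and higher numbers for an effect only at larger amounts of compound.

Three members share one core and differ only in the aryl group on the sulfonyl sulfur. Compound 1 `COc1ccc(-c2cc(=O)c3c(OC)cc(OC)cc3n2S(=O)(=O)c2ccc(C=O)cc2)cc1` carries a 4-formylphenyl there; in this assay compound 1 reaches only a limit, > 34400 nM. Compound 2 `COc1ccc(-c2cc(=O)c3c(OC)cc(OC)cc3n2S(=O)(=O)c2cccc([N+](=O)[O-])c2)cc1` carries a 3-nitrophenyl; in this assay compound 2 likewise gives only a limit, > 39600 nM. Compound 3 `COc1ccc(-c2cc(=O)c3c(OC)cc(OC)cc3n2S(=O)(=O)c2ccc(F)cc2)cc1` carries a 4-fluorophenyl; in this assay compound 3 also gives only a limit, > 65500 nM. From the compounds shown here alone, because all three values are limits, none of the steps among them can be read: a step that the two limits leave unreadable from compound 1 to compound 2, a step that the two limits leave unreadable from compound 1 to compound 3 and a step that the two limits leave unreadable from compound 2 to compound 3 remain open in size and direction. Compound 3 therefore stands at a limit like the two others, with no number to place it against them.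

Compound 4 `COc1ccc(-c2cc(=O)c3c(OC)cc(OC)cc3n2S(=O)(=O)c2c(F)c(F)c(F)c(F)c2F)cc1` is the next member: 2,3,4,5,6-pentafluorophenyl in place of 4-fluorophenyl on a sulfonyl sulfur. Among the measured compounds shown here, no measured step speaks to this exchange, and every comparison so far ended at a limit, as the limit of > 34400 nM in this assay, at which 1 of the 3 values shown sits, the limit of > 39600 nM in this assay, at which 1 of the 3 values shown sits, and the limit of > 65500 nM in this assay, at which 1 of the 3 values shown sits, record. The expectation for the step of an at least 1.0-fold lower number from compound 3 to compound 4 (0.03 log units; that floor lies within the scatter) is accordingly not a readable shift but a further limit. Compound 4 is estimated in this assay at 60000 nM, in the range 12000 nM to 250000 nM, most probably again reported as a limit.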

Compound 4, half-maximal effective concentration: 4100 nM
Estimate against measurement, compound 4: 15-fold (1.17 log units) above; measured number outside the range, below it.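

In this assay, among the compounds shown here, compound 4 is the first member of the series to give a number and not a limit, which shows that the group on this sulfonyl sulfur can move the read-out: 2,3,4,5,6-pentafluorophenyl in place of 4-fluorophenyl gives an at least 15-fold lower number from compound 3 to compound 4 (1.20 log units; beyond the scatter). The same group in place of the two other aryl groups gives an at least 9.6-fold lower number from compound 2 to compound 4 (0.98 log units; beyond the scatter) and an at least 8.3-fold lower number from compound 1 to compound 4 (0.92 log units; beyond the scatter), so at this position it stands apart from all three earlier groups, while the steps among compounds 1, 2 and 3 themselves cannot be read. The values shown record only limits for those three compounds and give no cause for the shift.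

From the compounds shown here alone, it remains open whether a 2,6-difluorophenyl or a 3,5-difluorophenyl on the sulfonyl sulfur would keep a readable number or return to a limit, and so whether all five fluorine atoms of compound 4 are needed. Also open, going by these compounds, is what an amine or a carboxylic acid on that aryl ring would do to the number of compound 4.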